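Extending the Saturated Chain of Compound 3

The source may report more compounds than this note shows. Statements on the series, on what has been measured and on what is new or still open speak of the compounds shown alone.

Compound 1 `CCCCCC(CCO)n1cnc2c(Cl)nc(Cl)nc21` gives 6010 nM in a functional assay on SW480 cells (Homo sapiens) for antiproliferative activity, read by MTT assay, with a stated time of 48 h (a lower number here means a stronger inhibitor, a higher number a weaker inhibitor), as its measured result. Compound 2 `CCCCCCCC(CCO)n1cnc2c(Cl)nc(Cl)nc21` shares the same core with a longer saturated chain and gives 13600 nM in this assay as well. Compound 3 `CCCCCCCCC(CCO)n1cnc2c(Cl)nc(Cl)nc21` has a longer chain still and gives 24000 nM on the same read-out.

The data show a 1.8-fold higher number from compound 2 to compound 3 (0.25 log units; within the scatter) so compound 3 cannot be told apart from compound 2. They also show a 4.0-fold higher number from compound 1 to compound 3 (0.60 log units; beyond the scatter) as a real gap from compound 1.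

Compound 4 `CCCCCCCCCC(CCO)n1cnc2c(Cl)nc(Cl)nc21` extends the chain further, and methyl in place of hydrogen on a saturated chain carbon, nine bonds along the chain from an aromatic nitrogen is its whole difference from compound 3: methyl in place of hydrogen on a saturated chain carbon, nine bonds along the chain from an aromatic nitrogen.

Within the data shown here, the closest precedent is the same swap eight bonds along the chain, which gave a 1.8-fold higher number from compound 2 to compound 3 (0.25 log units; within the scatter) as a small result. The larger swap of ethyl for hydrogen gave a 2.3-fold higher number from compound 1 to compound 2 (0.35 log units; beyond the scatter) as a modest rise. All three measured steps point upward, though only two clear the scatter.

A small further rise is therefore expected, with the estimated size being a 1.5-fold higher number from compound 3 to compound 4 (0.18 log units; within the scatter) and no clear move beyond the scatter anticipated. For compound 4 the estimated value is 36000 nM with 20000 nM to 65000 nM as the expected range.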

Compound 4, half-maximal inhibitory concentration: 36300 nM
The estimate for compound 4 lay 1.0-fold (0.00 log units) below the measured number, and the stated range covers the measured number.
By their numbers in this assay, from the lowest: compound 1; then compounds 2, 3 and 4 (each within the scatter of the next, the first and the last beyond it).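

In this assay, methyl in place of hydrogen on a saturated chain carbon, nine bonds along the chain from an aromatic nitrogen, gives a 1.5-fold higher number from compound 3 to compound 4 (0.18 log units; within the scatter), so this single extension cannot be told apart from the ordinary spread of repeat measurements. Across a larger change the picture is clearer: ethyl in place of hydrogen eight bonds along the chain gives a 2.7-fold higher number from compound 2 to compound 4 (0.43 log units; beyond the scatter), and butyl in place of hydrogen six bonds along the chain gives a 6.0-fold higher number from compound 1 to compound 4 (0.78 log units; beyond the scatter). Compound 4 therefore stands apart from compound 2, which compound 3 did not, showing that among these four compounds a longer chain goes with weaker activity only when the extension spans more than one carbon, and no compound here goes against that reading.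

No supporting measurement bears on what lies behind these steps. From the compounds shown here alone, it remains open whether a chain shorter than that of compound 1 would give a lower number, and whether an amine or a carboxylic acid at the far end of the chain would change the outcome.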